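Swapping an amide for an alkylamine on the shared core

The source may report more compounds than this note shows. Statements on the series, on what has been measured and on what is new or still open speak of the compounds shown alone.

Measured in a functional assay on HCT-116 cells (Homo sapiens) for antiproliferative activity, read by sulforhodamine B assay, with a stated time of 72 h; on this read-out lower numbers stand for stronger inhibition and higher numbers for weaker inhibition:
compound 1 `COc1ncc(-c2ccc3ncc(NC(=O)C4CCCCC4)c(OC)c3c2)cc1NS(=O)(=O)c1ccc(F)cc1F`: 4610 nM
compound 2 `CCNc1cnc2ccc(-c3cnc(OC)c(NS(=O)(=O)c4ccc(F)cc4F)c3)cc2c1OC`: 1850 nM
compound 3 `COc1ccc(CNc2cnc3ccc(-c4cnc(OC)c(NS(=O)(=O)c5ccc(F)cc5F)c4)cc3c2OC)cc1`: 10200 nM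

Compound 1, at 4610 nM, holds the second highest of the three numbers. The change to compound 4 `COc1ncc(-c2ccc3ncc(NCC4CCN(C(C)=O)CC4)c(OC)c3c2)cc1NS(=O)(=O)c1ccc(F)cc1F` is (1-acetylpiperidin-4-yl)methyl in place of cyclohexylcarbonyl on a nitrogen on an aromatic ring. Two measured steps also remove the cyclohexylcarbonyl. Ethyl gave a 2.5-fold lower number from compound 1 to compound 2 (0.40 log units; beyond the scatter), and 4-methoxybenzyl gave a 2.2-fold higher number from compound 1 to compound 3 (0.34 log units; beyond the scatter). These steps are modest and opposite in direction, and the two entering groups themselves differ by a 5.5-fold higher number from compound 2 to compound 3 (0.74 log units; beyond the scatter). Among the compounds with values here, no measured compound carries a non-aromatic ring with a hetero atom at this place, so neither direction is favoured in this assay, and no step beyond the scatter is expected. The expected step is a 1.2-fold lower number from compound 1 to compound 4 (0.06 log units; within the scatter). For compound 4 the estimated value is 4000 nM, with an expected range from 1500 nM to 11000 nM.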

Compound 4, half-maximal inhibitory concentration: 1930 nM
Compound 4: the middle estimate sits 2.1-fold (0.32 log units) above what was measured, within the range that was stated.
By their numbers in this assay, from the lowest: compounds 2 and 4 (each within the scatter of the next); then compound 1; then compound 3.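

In this assay the step of a 2.4-fold lower number from compound 1 to compound 4 (0.38 log units; beyond the scatter) shows that a non-aromatic ring with a hetero atom can sit on this nitrogen with the number still falling, and a 5.3-fold lower number from compound 3 to compound 4 (0.72 log units; beyond the scatter) shows 1-acetylpiperidin-4-yl doing better here than 4-methoxyphenyl. The step of a 1.0-fold higher number from compound 2 to compound 4 (0.02 log units; within the scatter) stays within the scatter, so this much larger group matches plain ethyl. No measured evidence explains these steps. It remains open whether the acetyl itself matters, since a free piperidine amine is not among these compounds. A morpholine ring at this place is equally untested in what is shown.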